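This account rests on a few compounds, and the source may have more. Where it says the series, first, only, none or still open, it means among the compounds named here.

Of the compounds shown here, three sharing one core have been measured in an ADME assay on microsomes from liver (Mus musculus) for metabolic stability, read by LC-MS, using NADPH, with a stated time of 10 min, tested at 10 uM; a lower number here means that the compound disappears faster, a higher number that the compound lasts longer. Compound 1 `Nc1ncnc2c1c(Oc1cccc(C(F)(F)F)c1)nn2[C@H]1C[C@H](O)C1` gives 0.367 h. Compound 2 `N#Cc1ccnc(Oc2nn(C3CCC3)c3ncnc(N)c23)c1` gives 0.4 h, which is the highest of the three numbers, though its gap to compound 1 lies within the scatter. Compound 3 `CO[C@H]1CC[C@H](n2nc(Oc3cc(C(F)(F)F)ccn3)c3c(N)ncnc32)CC1` gives 0.217 h, and here too the gap to compound 2 lies within the scatter, so no ordering among the three can be claimed. Compound 4 `Nc1ncnc2c1c(Oc1cc(Cl)ccn1)nn2C1CCC1` has not yet been measured in this assay. It differs from compound 2 in one place: chloro in place of cyano on an aromatic carbon. Among the compounds with values here, no pair of measured compounds shows this change, so its effect cannot be read from a step between them; the only guide is that the three measured values sit close together. The expectation is therefore a small step, a 1.1-fold lower number from compound 2 to compound 4 (0.06 log units; within the scatter), not beyond the scatter in either direction. Compound 4 is expected to give 0.35 h, with a range from 0.18 h to 0.7 h.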

Compound 4, half-life: 0.0617 h
The estimate for compound 4 lay 5.7-fold (0.75 log units) above the measured number, outside the stated range (below it).
By their numbers in this assay, from the lowest: compound 4; then compounds 3, 1 and 2 (each within the scatter of the next).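

In this assay, within the data shown here, the aromatic carbon opposite the ring nitrogen proves sensitive to a single change: chloro in place of cyano gives a 6.5-fold lower number from compound 2 to compound 4 (0.81 log units; beyond the scatter), a step beyond the scatter, whereas the earlier compounds showed no gap that could be read. Among these compounds, this is the first step between compounds that differ in one place, so it shows that one change on this carbon can shift the half-life by more than repeat measurements would. Nothing available explains why the number falls with chloro in place of cyano.

Going by these compounds, what a methyl group or an amine on this same carbon would give remains open. So does whether chloro in place of cyano produces a step of similar size elsewhere in the series.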